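Methoxy to Chloro on the Aryl Ring: Compound 4

A few compounds are considered here, and "the series" means these few. Any claim that something is new, unique, unknown or untested is made for them only; others in the source may bear on it.

Compound 1 `COc1ccc(-n2nc(C(=O)Nc3ccc(Oc4ccnc5cc(OCCCN6CCCC6)c(OC)cc45)c(F)c3)c(C)cc2=O)cc1` — 2960 nM
Compound 2 `COc1ccc(-n2nc(C(=O)Nc3ccc(Oc4ccnc5cc(OCCCN6CCCCC6)c(OC)cc45)c(F)c3)c(C)cc2=O)cc1` — 1800 nM
Compound 3 `COc1ccc(-n2nc(C(=O)Nc3ccc(Oc4ccnc5cc(OCCCN6CCN(C)CC6)c(OC)cc45)c(F)c3)c(C)cc2=O)cc1` — "not determined" (no result reported)
Compound 4 `COc1cc2c(Oc3ccc(NC(=O)c4nn(-c5ccc(Cl)cc5)c(=O)cc4C)cc3F)ccnc2cc1OCCCN1CCN(C)CC1` — to be measured

In a functional assay on U-87MG ATCC cells (Homo sapiens) for inhibition, read by MTT assay, with a stated time of 72 h (on this read-out higher numbers stand for weaker inhibition and lower numbers for stronger inhibition), compound 1 gives 2960 nM and compound 2 gives 1800 nM; the step of a 1.6-fold lower number from compound 1 to compound 2 (0.22 log units; within the scatter) is the only one measured, and it concerns the amine on the chain, not the ring at the other end. Compound 3, which carries a 4-methylpiperazin-1-yl in that place, is reported as "not determined" (no result reported) in this assay, so it stands without a value; its neighbours compound 1 and compound 2 both lie in the low-micromolar region and within the scatter of each other.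

Compound 4 differs from compound 3 by chloro in place of methoxy on an aromatic carbon. No measured pair carries this change, so nothing among the numbers shown bears on its size or direction. The account therefore rests on the region occupied by compound 1 and compound 2 and on the expectation that the chain change between them was within the scatter. On that basis compound 4 is expected in this assay to give about 2200 nM, with an estimated range from 600 nM to 8000 nM; whether the chloro shifts the number beyond the scatter cannot be told from what is known.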

Compound 4, half-maximal inhibitory concentration: 1560 nM
Compound 4: the middle estimate sits 1.4-fold (0.15 log units) above what was measured, within the range that was stated.
By their numbers in this assay, from the lowest: compounds 4, 2 and 1 (each within the scatter of the next).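

Within the data shown here, because compound 3 has no single number in this assay, no step from compound 3 to compound 4 can be read. Nothing further is available that bears on the result for compound 4. Going by these compounds, what 4-chlorophenyl in place of 4-methoxyphenyl does to the number, with the 4-methylpiperazin-1-yl chain held the same, stays open.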